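The source may hold more compounds than are shown below. What is called first, only, known or untested is meant among the compounds shown, and "the series" means these compounds.

Within the shared core, compound 3 `CN(C(=O)c1ccco1)c1ccc2[nH]c(-c3n[nH]c4ccccc34)cc2n1` gives 30000 nM in a functional assay on HCT-116 cells (Homo sapiens) for antiproliferative activity, read by MTT assay, with a stated time of 72 h (a higher number here means a weaker inhibitor, a lower number a stronger inhibitor), the highest of the three numbers. Compound 1 `CN(C(=O)C(C)(C)C)c1ccc2[nH]c(-c3n[nH]c4ccccc34)cc2n1` gives 18000 nM in this assay, and compound 2 `CN(C(=O)c1ccc(F)cc1)c1ccc2[nH]c(-c3n[nH]c4ccccc34)cc2n1` gives 9270 nM. The steps of a 1.7-fold higher number from compound 1 to compound 3 (0.22 log units; within the scatter) and a 3.2-fold higher number from compound 2 to compound 3 (0.51 log units; beyond the scatter) place compound 3 at the top, though only the second of these lies beyond the scatter. Compound 4 `CN(c1ccc2[nH]c(-c3n[nH]c4ccccc34)cc2n1)S(=O)(=O)c1ccccc1` carries phenylsulfonyl in place of (furan-2-yl)carbonyl on a nitrogen on an aromatic ring. Among the compounds with values here, the nearest measured step is a 3.2-fold higher number from compound 2 to compound 3 (0.51 log units; beyond the scatter), an aryl group in place of the furan ring; no sulfonyl analogue has been measured, so the carbonyl-to-sulfonyl part of the change is untested. A modest lowering of the number is expected, a 2.5-fold lower number from compound 3 to compound 4 (0.40 log units; beyond the scatter), placing compound 4 at an estimated 12000 nM in this assay, with a range of 4000 nM to 40000 nM.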

Compound 4, half-maximal inhibitory concentration: 6740 nM
Compound 4: middle estimate off by 1.8-fold (0.25 log units), on the high side; the range from low to high includes it.
By their numbers in this assay, from the lowest: compounds 4, 2, 1 and 3 (each within the scatter of the next, the first and the last beyond it).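

Within the data shown here, this is the first change of the carbonyl itself on this nitrogen on an aromatic ring, and the sulfonyl linkage is tolerated: phenylsulfonyl replacing (furan-2-yl)carbonyl gives (a 4.5-fold lower number from compound 3 to compound 4 (0.65 log units; beyond the scatter)), and replacing (tert-butyl)carbonyl gives (a 2.7-fold lower number from compound 1 to compound 4 (0.43 log units; beyond the scatter)). Against (4-fluorophenyl)carbonyl the step (a 1.4-fold lower number from compound 2 to compound 4 (0.14 log units; within the scatter)) does not separate the sulfonyl from that amide. Nothing available bears on the origin of these steps.

Open, from the compounds shown here alone, are methylsulfonyl in place of phenylsulfonyl and a phenylsulfonyl carrying an amine or a carboxylic acid.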